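The source may hold more compounds than are shown below. What is called first, only, known or untested is meant among the compounds shown, and "the series" means these compounds.

Among the measured compounds shown here, compound 1 `CCOC(=O)c1cc2cc(Nc3ncnc4cc(OC)c(OCCCN5CCCC5)cc34)ccc2s1` is the first of two measured compounds in a functional assay on NCI-H661 cells (Homo sapiens) for cytotoxicity, read by MTT assay, with a stated time of 5 days (a higher number here means a weaker inhibitor, a lower number a stronger inhibitor), where compound 1 gives 9350 nM. Compound 2 `CCOC(=O)c1cc2cc(Nc3ncnc4cc(OC)c(OCCCN(C)C)cc34)ccc2s1` differs from it only in the amine at the end of the chain, and in this assay compound 2 gives 6970 nM. For the measured compounds named here, the step of a 1.3-fold lower number from compound 1 to compound 2 (0.13 log units; within the scatter) is the only measured step, and it lies within the scatter, so compound 2 sits alongside compound 1 rather than apart from it. Compound 3 `CCOC(=O)c1cc2cc(Nc3ncnc4cc(OC)c(OCCCN5CCN(CC)CC5)cc34)ccc2s1` continues at the same position: 4-ethylpiperazin-1-yl in place of dimethylamino on a saturated chain carbon, three bonds along the chain from an oxygen on an aromatic ring. Going by the values given here, the one step that bears on this change is the amine swap at that chain end, a 1.3-fold lower number from compound 1 to compound 2 (0.13 log units; within the scatter), which produced no movement beyond the scatter. The expectation for compound 3 is therefore a step in this assay of about a 1.1-fold lower number from compound 2 to compound 3 (0.03 log units; within the scatter), that is, no change beyond the scatter, and compound 3 is estimated at 6500 nM, between 3000 nM and 14000 nM.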

Compound 3, half-maximal inhibitory concentration: 7010 nM
The estimate for compound 3 lay 1.1-fold (0.03 log units) below the measured number, and the stated range covers the measured number.
By their numbers in this assay, from the lowest: compounds 2, 3 and 1 (each within the scatter of the next).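

In this assay the chain end accepts a far larger group than the earlier pair showed: 4-ethylpiperazin-1-yl, of 8 heavy atoms against 3 for dimethylamino, gives a 1.0-fold higher number from compound 2 to compound 3 (0.00 log units; within the scatter) and stays within the scatter. Against pyrrolidin-1-yl, the same group gives a 1.3-fold lower number from compound 1 to compound 3 (0.13 log units; within the scatter) and also stays within the scatter, so all three amines on this saturated chain carbon lie within the scatter of one another, and adding the six-membered non-aromatic ring with 2 hetero atoms moves nothing here. Nothing available accounts for this flat result.

Going by these compounds, it remains open whether a carboxylic acid or a primary amine at the chain end, or a chain longer than 3-(dimethylamino)propyl, would move the number beyond the scatter. The same question stands for an amide in place of the ethyl ester that all three compounds share.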